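An isopropoxy group added to compound 2

A few compounds are considered here, and "the series" means these few. Any claim that something is new, unique, unknown or untested is made for them only; others in the source may bear on it.

Compound 1 `COc1ccc(C2=C(c3cc(OC)c(OC)c(OC)c3)C(=O)C(OC(C)=O)C2)cc1` and compound 2 `COc1ccc(C2=C(c3cc(OC)c(OC)c(OC)c3)C(=O)C(O)C2)cc1` share one core. In an ADME assay on DU-145 cells (Homo sapiens) for cytotoxicity, read by MTT assay, with a stated time of 72 h (a higher number here means a weaker inhibitor, a lower number a stronger inhibitor), compound 1 gives > 100 ug/mL, which is a limit of the assay and not a number. Compound 2 gives > 100 ug/mL, again only a limit. Compound 2 therefore stands at the limit of > 100 ug/mL in this assay, at which 2 of the 2 values shown sit. Compound 3 `COc1ccc(C2=C(c3cc(OC)c(OC)c(OC)c3)C(=O)C(O)C2)cc1OC(C)C` differs from it by isopropoxy in place of hydrogen on an aromatic carbon, with isopropoxy in place of hydrogen on an aromatic carbon. For the measured compounds named here, the only measured step is a step that the two limits leave unreadable from compound 1 to compound 2, and it changes a different place, so it offers no size or direction to carry over. The expected step is a number no higher from compound 2 to compound 3 (the limit leaves the size open), with nothing beyond the scatter foreseen. For compound 3 the estimate is 100 ug/mL, within a range of 40 ug/mL to 200 ug/mL.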

Compound 3, half-maximal inhibitory concentration: > 100 ug/mL
Compound 3: no number, only a limit (the forecaster's own chance of this, stated with the estimate: 65%); the middle value lies on the limit itself.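

Compound 2 and compound 3 each give only a limit of the assay, not a number, so the step between them cannot be read. The compounds shown leave open whether any change to the shared core would give a readable number, since all remain at one limit: the limit of > 100 ug/mL in this assay, at which 3 of the 3 values shown sit.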